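Removing One Methyl Group and Its Cost in Growth Inhibition

The source may hold more compounds than are shown below. What is called first, only, known or untested is meant among the compounds shown, and "the series" means these compounds.

Of the compounds shown here, three have been tested in a functional assay on SF-295 cells (Homo sapiens) for antiproliferative activity; on this read-out higher numbers stand for weaker inhibition of growth and lower numbers for stronger inhibition of growth. Compound 1 `Oc1cc(-c2ccc3ccccc3c2)nc2ncccc12` gives 9120 nM. Compound 2 `Cc1cc(C)c2c(O)cc(-c3cccc4ccccc34)nc2n1` gives 589 nM, and compound 3 `Cc1cnc2nc(-c3ccc4ccccc4c3)cc(O)c2c1` gives 550 nM; the values of compound 2 and compound 3 lie within the scatter of each other. Compound 3 and compound 1 differ in one place: hydrogen in place of methyl on an aromatic carbon This change gave a 17-fold higher number from compound 3 to compound 1 (1.22 log units; beyond the scatter), a large loss of growth inhibition.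

Compound 4 `Cc1ccc2c(O)cc(-c3cccc4ccccc34)nc2n1` has not yet been measured. It arises from compound 2 by the same kind of change: hydrogen in place of methyl on an aromatic carbon The surroundings are not identical, though: in compound 3 the methyl sat two atoms from the ring nitrogen, meta to a fused ring and para to a fused ring, whereas in compound 2 it sits ortho to a fused ring, meta to a fused ring, meta to a methyl group and opposite the ring nitrogen. The cores of compound 2 and compound 3 differ in a way that is not broken down here. In this assay the step is expected to be a 5.1-fold higher number from compound 2 to compound 4 (0.71 log units; beyond the scatter), a weakening that rests on a 17-fold higher number from compound 3 to compound 1 (1.22 log units; beyond the scatter) but is taken as smaller, as the place is not the same and a methyl remains in compound 4. Compound 4 is therefore expected to give about 3000 nM, between 900 nM and 10000 nM.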

Compound 4, concentration for 50% growth inhibition: 24 nM
Estimate against measurement, compound 4: 130-fold (2.10 log units) above; the whole stated range lies above it.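

Replacing a methyl group with hydrogen gave a 25-fold lower number from compound 2 to compound 4 (1.39 log units; beyond the scatter) in this assay, a large gain in growth inhibition, whereas the same kind of change gave a 17-fold higher number from compound 3 to compound 1 (1.22 log units; beyond the scatter), a large loss. The two steps run in opposite directions, and the gap between them is larger than scatter alone would explain: the same change on two cores in this assay, a 17-fold higher number (1.22 log units; beyond the scatter) from compound 3 to compound 1 and a 25-fold lower number (1.39 log units; beyond the scatter) from compound 2 to compound 4, 410-fold (2.61 log units) apart, beyond the scatter of two such steps. This shows that, in this series, the result of removing a methyl group on one core cannot be carried over to another, but two pairs do not show whether the place of the methyl, the rest of the core or both set the direction, and they give no reason for the reversal.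

The compounds shown leave open what replacing the remaining methyl group of compound 4 with hydrogen would do. They also leave open how an ethyl group or an amine would behave in the place the methyl group left.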